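The source may report more compounds than this note shows. Statements on the series, on what has been measured and on what is new or still open speak of the compounds shown alone.

Compound 1 `Cc1ccc(NC(=O)Nc2nc(Nc3ccccc3)cc(Sc3c[nH]c4ccccc34)n2)cc1` — 14900 nM
Compound 2 `COc1ccc(NC(=O)Nc2nc(Sc3c[nH]c4ccccc34)cc(N3CCN(Cc4ccccc4)CC3)n2)cc1` — 21400 nM
Compound 3 `Cc1cc(Cl)ccc1NC(=O)Nc1nc(Nc2ccccc2)cc(Sc2c[nH]c3ccccc23)n1` — 8370 nM

All three compounds were tested in a functional assay on HepG2 cells (Homo sapiens) for inhibition, with a stated time of 72 h; on this read-out lower numbers stand for stronger inhibition and higher numbers for weaker inhibition. Among the three, compound 2 has the highest number. Its nearest neighbour is compound 1, with a difference that lies within the scatter, so the two cannot be told apart; compound 3 lies furthest away, and that gap is beyond the scatter. Within the data shown here, the only step between two measured compounds that differ in one place is a 1.8-fold lower number from compound 1 to compound 3 (0.25 log units; within the scatter), a change of the aryl group on the amide-type nitrogen of the urea, which itself lies within the scatter.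

Compound 4 `Cc1ccc(C)c(NC(=O)Nc2nc(Sc3c[nH]c4ccccc34)cc(N3CCN(Cc4ccccc4)CC3)n2)c1` has not yet been measured. It differs from compound 2 by 2,5-dimethylphenyl in place of 4-methoxyphenyl on an amide-type nitrogen. Among the measured compounds shown here, this is the same kind of change as the one observed between compound 1 and compound 3, an exchange of the aryl group on the amide-type nitrogen, and that step was small. Compound 4 is therefore expected to stay close to compound 2, with at most a modest move towards a lower number. The estimate for compound 4 in this assay is 16000 nM, with a range from 7000 nM to 36000 nM. The expected step is a 1.3-fold lower number from compound 2 to compound 4 (0.13 log units; within the scatter).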

Compound 4, half-maximal inhibitory concentration: 16400 nM
The estimate for compound 4 lay 1.0-fold (0.01 log units) below the measured number, and the stated range covers the measured number.
By their numbers in this assay, from the lowest: compounds 3, 1, 4 and 2 (each within the scatter of the next, the first and the last beyond it).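

Compound 4 brings a second reading of the aryl exchange on the amide-type nitrogen, this time in the core of compound 2, and in this assay the exchange gives a 1.3-fold lower number from compound 2 to compound 4 (0.12 log units; within the scatter). Among these compounds, until now the only such reading was a 1.8-fold lower number from compound 1 to compound 3 (0.25 log units; within the scatter) in the core of compound 1, so both cores now show an exchange at this position that stays within the scatter. The new pair also differs in its count of atoms: 4-methoxyphenyl carries an oxygen and a hydrogen-bond acceptor while 2,5-dimethylphenyl carries neither, and with the heavy-atom count unchanged this replacement leaves compound 2 and compound 4 indistinguishable in this assay, although no measurement is at hand that would explain the result.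

Every group shown on this nitrogen is a phenyl ring bearing methyl, methoxy or chloro substituents, so it remains open whether a cyclohexyl ring, a pyridine ring, or a phenyl ring carrying a carboxylic acid or an amine would give a step beyond the scatter. Going by these compounds, it also remains open whether 4-chloro-2-methylphenyl would read the same in the core of compound 2 as it does in the core of compound 3.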